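Adding chloro to compound 2: working notes

The source may report more compounds than this note shows. Statements on the series, on what has been measured and on what is new or still open speak of the compounds shown alone.

In a functional assay on V79 cells (Cricetulus griseus) for cytotoxicity, read by colony formation (a lower number here means a stronger inhibitor, a higher number a weaker inhibitor), compound 2 `NC1CCN(c2cc3c(cc2F)c(=O)c(C(=O)O)cn3C2CC2)CC1` gives 230 ug/mL, the only single number shown for it, and one further entry carries no single number. In this assay compound 1 `CCNCC1CCN(c2c(F)cc3c(=O)c(C(=O)O)cn(C4CC4)c3c2Cl)C1` gives 11 ug/mL; 11 ug/mL; < 11 ug/mL (3 entries). One of these entries for compound 1 is a limit and not a number.

The next step leads to compound 3 `NC1CCN(c2c(F)cc3c(=O)c(C(=O)O)cn(C4CC4)c3c2Cl)CC1`, with chloro in place of hydrogen on an aromatic carbon. The new chloro stands ortho to the 4-aminopiperidin-1-yl group, which compound 3 keeps from compound 2.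

Among the compounds with values here, no step between measured compounds isolates this change, since compound 1 and compound 2 differ in more than one place. The expectation rests on compound 1, which has chloro on the same aromatic carbon and gives 11 ug/mL; 11 ug/mL; < 11 ug/mL (3 entries), but it carries a different amine, so only part of the gap to compound 2 is expected to be crossed. The expected step is a 5.8-fold lower number from compound 2 to compound 3 (0.76 log units; beyond the scatter), toward a lower number and beyond the scatter. For compound 3 the estimated value is 40 ug/mL, with an expected range from 12 ug/mL to 130 ug/mL.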

Compound 3, half-maximal inhibitory concentration: 18 ug/mL
Compound 3: middle estimate off by 2.2-fold (0.35 log units), on the high side; the measured number falls inside the stated range.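

In this assay, within the data shown here, this is the first step that isolates the change: with the 4-aminopiperidin-1-yl group kept, chloro in place of hydrogen on this aromatic carbon gives a 13-fold lower number from compound 2 to compound 3 (1.11 log units; beyond the scatter), a large step. Among these compounds, until now, chloro at this place could be seen only in compound 1, where a different amine stood with it, so the contribution of the chloro could not be told apart from that of the amine; the present pair separates the two and shows that the chloro alone is enough for a step beyond the scatter. One of the entries for compound 1, which carries chloro on the same aromatic carbon, is a limit and not a number: the several entries of compound 1 in this assay, 11 ug/mL; 11 ug/mL; < 11 ug/mL (3 entries).

As far as these compounds go, whether a bromo or a methoxy group on this aromatic carbon would move the number as chloro does remains open. From the compounds shown here alone, what lies behind the step also remains open, as does whether it carries over when a piperazine stands in place of the 4-aminopiperidin-1-yl group.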